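Dimethylamino in place of methyl on the aryl ring

The source may report more compounds than this note shows. Statements on the series, on what has been measured and on what is new or still open speak of the compounds shown alone.

Of the compounds shown here, two that share one core have been measured so far. Compound 1 `COc1cc(/C=C/C(=O)C2=C(/C=C/c3ccc(O)c(OC)c3)NC(=O)NC2c2ccccc2Cl)ccc1O` carries a chlorine-bearing aryl group, and compound 2 `COc1cc(/C=C/C(=O)C2=C(/C=C/c3ccc(O)c(OC)c3)NC(=S)NC2c2ccc(C)cc2)ccc1O` carries a methyl-bearing aryl group. In a functional assay, with a stated time of 20 min, tested at 10 uM (a lower number here means a weaker effect, a higher number a stronger effect of the compound at the concentration tested), compound 2 gives 43.2%, and compound 1 gives 40%; the gap between these two numbers lies within the usual scatter, so nothing separates them with confidence. Compound 3 `COc1cc(/C=C/C(=O)C2=C(/C=C/c3ccc(O)c(OC)c3)NC(=S)NC2c2ccc(N(C)C)cc2)ccc1O` has not yet been measured. It differs from compound 2 in one place: dimethylamino in place of methyl on an aromatic carbon. Going by the values given here, no step between two measured compounds shows what such a change does to the read-out, so the direction of any shift is open. The change from compound 2 to compound 3 is expected to give a step of a number 1.8 percentage points higher from compound 2 to compound 3 (within the scatter), that is, none beyond the scatter. Compound 3 is therefore estimated at 45%, within a range from 25% to 65%.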

Compound 3, a percentage reported as activity, at one concentration (the size of the read-out at that concentration, not a potency): 72%
Beside the measured number, compound 3's estimate is 27 percentage points below it; the whole stated range lies below it.
By their numbers in this assay, from the lowest: compounds 1 and 2 (each within the scatter of the next); then compound 3.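

Going by these compounds alone, this is the only step here between two compounds that differ in one place, and it shows that the group on this aromatic carbon, para to a large group, can change the read-out. In this assay the move from 4-methylphenyl to 4-(dimethylamino)phenyl gives a step of a number 28.8 percentage points higher from compound 2 to compound 3 (beyond the scatter) while the rest of the molecule stays the same. Nothing measured here explains why this exchange has such an effect.

One step cannot tell whether a plain amine, a methoxy group or a longer chain in the same place would give a similar read-out. It also leaves open whether dimethylamino would have the same effect on the core of compound 1, which differs from compound 2 in more than one place.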